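A few compounds are considered here, and "the series" means these few. Any claim that something is new, unique, unknown or untested is made for them only; others in the source may bear on it.

Measured compounds in an assay on cells for agonist activity at ecdysone receptor (Bombyx mori), read by a luciferase reporter, with a stated time of 24 h; a higher number here means that more compound is needed for the effect, a lower number that less compound is needed:

Compound 1 `CC(C)(C)N(NC(=O)c1ccc(C#N)cc1)C(=O)c1ccccc1Cl`: 603 nM
Compound 2 `CCc1ccc(C(=O)NN(C(=O)c2ccccc2Cl)C(C)(C)C)cc1`: 5.75 nM

For the measured compounds named here, of the two compounds measured, compound 2 stands at the lower number: it needs far less compound than compound 1, and the only measured step, a 100-fold lower number from compound 1 to compound 2 (2.02 log units; beyond the scatter), comes from ethyl in place of cyano on an aromatic carbon. Compound 2 therefore marks the favourable end of what is known here.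

Compound 3 `CCCc1ccc(C(=O)NN(C(=O)c2ccccc2Cl)C(C)(C)C)cc1` has not yet been measured in this assay. It differs from compound 2 by methyl in place of hydrogen on a saturated chain carbon, two bonds along the chain from an aromatic carbon, so the ethyl of compound 2 becomes a propyl. Going by the values given here, no measured step compares two alkyl chains of different length on that carbon; the one measured step, a 100-fold lower number from compound 1 to compound 2 (2.02 log units; beyond the scatter), swapped a nitrile for an alkyl and says little about lengthening the alkyl by one carbon. Among the compounds with values here, with that step as the only guide, the account expects for compound 3 a step of a 1.4-fold higher number from compound 2 to compound 3 (0.14 log units; within the scatter), that is, no change beyond the scatter, or at most a small one in either direction. Compound 3 is thus estimated at 8 nM, in a range from 2.5 nM to 25 nM.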

Compound 3, half-maximal effective concentration: 9.12 nM
The estimate for compound 3 lay 1.1-fold (0.06 log units) below the measured number; the range from low to high includes it.
By their numbers in this assay, from the lowest: compounds 2 and 3 (each within the scatter of the next); then compound 1.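

In this assay, extending the ethyl of compound 2 to the propyl of compound 3 gives a 1.6-fold higher number from compound 2 to compound 3 (0.20 log units; within the scatter) and so lies within the scatter: at this position the assay does not separate the two alkyl chains. For the compounds shown here, until now the position had been read only through a single nitrile and a single alkyl chain, and the new pair adds the first comparison of one alkyl chain with another. The large step away from the nitrile also appears with propyl, as a 66-fold lower number from compound 1 to compound 3 (1.82 log units; beyond the scatter) shows, so it is not confined to ethyl, although no evidence at hand explains the distance between the nitrile and either alkyl chain.

The compounds shown leave open whether a longer chain such as butyl, or a branched one such as isopropyl, on the same aromatic carbon would stay within the scatter of compound 2 and compound 3 or move away from them. They also leave open whether a methoxy group or an amine in that place would fall nearer the alkyl chains or nearer the nitrile of compound 1.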